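The source may report more compounds than this note shows. Statements on the series, on what has been measured and on what is new or still open speak of the compounds shown alone.

Compound 1 `O=C(CCCc1ccccc1)Nc1nc2ccccc2c(=O)s1` is a saturated three-carbon chain between the amide and the phenyl; compound 3 `O=C(C/C=C/c1ccccc1)Nc1nc2ccccc2c(=O)s1` carries the same phenyl on an unsaturated chain, and compound 2 `O=C(C/C=C/c1cccc(Cl)c1)Nc1nc2ccccc2c(=O)s1` adds a chloro to that phenyl. In an assay on CHO cells for displacement of a labelled ligand from adenosine receptor A1 (Homo sapiens), read by scintillation counting, with a stated time of 90 min (a lower number here means a stronger inhibitor, a higher number a weaker inhibitor), compound 1 gives 2500 nM, compound 3 gives 822 nM and compound 2 gives 562 nM. How the cores of compound 1 and compound 3 differ is not broken down here. The change chloro in place of hydrogen on an aromatic carbon made the step of a 1.5-fold lower number from compound 3 to compound 2 (0.17 log units; within the scatter).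

Compound 4 `O=C(CCCc1ccccc1)Nc1nc2cc(Cl)ccc2c(=O)s1` differs from compound 1 by chloro in place of hydrogen on an aromatic carbon. This is the same kind of change as from compound 3 to compound 2, but not the same: in compound 2 the chloro stands meta to a large group on a six-membered aromatic ring of carbon only, whereas in compound 4 it enters a ring that is part of a fused or bridged system of two rings, meta to a fused ring and para to a fused ring. Going by the values given here, the only measured example, a 1.5-fold lower number from compound 3 to compound 2 (0.17 log units; within the scatter), lies within the scatter, and the ring that receives the chloro is a different one, so the expected step of a 1.4-fold lower number from compound 1 to compound 4 (0.14 log units; within the scatter) in this assay is small and uncertain, resting on compound 1 at 2500 nM. Compound 4 is therefore estimated at 1800 nM in this assay, expected between 700 nM and 4500 nM.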

Compound 4, inhibition constant: 785 nM
Compound 4: the middle estimate sits 2.3-fold (0.36 log units) above what was measured; the range from low to high includes it.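

In this assay, chloro in place of hydrogen on an aromatic carbon of the ring system shared with the core gave a 3.2-fold lower number from compound 1 to compound 4 (0.50 log units; beyond the scatter), a modest step that, unlike the earlier one, stands clear of the scatter. Set beside that earlier step on the phenyl of compound 3, the two do not separate: the same change on two cores in this assay, a 1.5-fold lower number (0.17 log units; within the scatter) from compound 3 to compound 2 and a 3.2-fold lower number (0.50 log units; beyond the scatter) from compound 1 to compound 4, 2.2-fold (0.34 log units) apart, within the scatter of two such steps This shows that the change gave no lower number of a clearly different size on the two cores, but with only two examples, on different rings, it does not show that a step of one fixed size carries from core to core.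

The compounds shown leave open what a chloro would do on the phenyl of compound 1, or on the fused ring of compound 3, which would separate the effect of the ring from that of the chain. They also leave open whether a fluoro group, a methoxy group or an amine at the same place would give a step like that of the chloro.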